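Indole Gives Way to Indazole on a Shared Core

The compounds below may be only part of what the source reports. "The series", "measured", "known", "first", "only" and "open" are said of these compounds alone.

Three compounds share one core and differ in the bicyclic group attached to it. Compound 1 `COc1cc(-c2ccnc3cc(-c4cn(CO)c5ccccc45)nn23)cc(OC)c1OC` carries that group on a five-membered ring nitrogen bearing a hydroxymethyl; in a functional assay on A549 cells (Homo sapiens) for inhibition, read by CCK-8 assay, with a stated time of 48 h (a higher number here means a weaker inhibitor, a lower number a stronger inhibitor), compound 1 gives 167 nM. Compound 2 `COc1cc(-c2cc3nccc(-c4c[nH]c5ccccc45)n3n2)cc(OC)c1OC` places the same unsubstituted indole on a differently joined core, and in this assay compound 2 reaches only a limit, > 10000 nM. Compound 3 `COc1cc(-c2ccnc3cc(-c4ccc5c(ccn5C)c4)nn23)cc(OC)c1OC` gives 15 nM in this assay, the lowest of the two numbers shown; its gap to compound 1 lies beyond the usual scatter. Compound 2 contributes only the limit (the limit of > 10000 nM in this assay, at which 1 of the 3 values shown sits).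

Compound 4 `COc1cc(-c2ccnc3cc(-c4ccc5cnn(C)c5c4)nn23)cc(OC)c1OC` has not yet been tested. It differs from compound 3 in one place: 1-methyl-1H-indazol-6-yl in place of 1-methyl-1H-indol-5-yl on an aromatic carbon. Among the compounds with values here, no measured pair shows this change, so the account rests on expectation alone. The step from compound 3 to compound 4 is expected to be small, a 1.7-fold higher number from compound 3 to compound 4 (0.22 log units; within the scatter), not clearly beyond the scatter in either direction. Compound 4 is therefore estimated at 25 nM in this assay, within a range from 8 nM to 80 nM.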

Compound 4, half-maximal inhibitory concentration: 233 nM
Estimate against measurement, compound 4: 9.3-fold (0.97 log units) below, outside the stated range (above it).
By their numbers in this assay, from the lowest: compound 3; then compounds 1 and 4 (each within the scatter of the next). At a limit, above all of these: compound 2.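

In this assay, within the data shown here, replacing 1-methyl-1H-indol-5-yl with 1-methyl-1H-indazol-6-yl gives a 16-fold higher number from compound 3 to compound 4 (1.19 log units; beyond the scatter), the first direct reading of a single change at this position, so the number here depends strongly on which bicyclic group is present. The two groups have the same heavy-atom count and no hydrogen-bond donors, so those shared counts do not protect the number from a large step. No measurement shown here accounts for the size of this step.

The step combines two differences, a second ring nitrogen and a different point of attachment, and the compounds shown do not separate them. On these data alone, the effect of 1-methyl-1H-indazol-5-yl, which would keep the attachment number of compound 3 while adding the second ring nitrogen, remains open, as does that of an amine on the six-membered ring.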